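The source may hold more compounds than are shown below. What is called first, only, known or untested is meant among the compounds shown, and "the series" means these compounds.

Working notes on the series. In a toxicity assay on L02 cells (Homo sapiens) for cytotoxicity, read by MTT assay, with a stated time of 72 h (a higher number here means a weaker inhibitor, a lower number a stronger inhibitor), compound 1 `O=C1c2c[n+]([O-])c3ccccc3c2C(=O)c2c1c1ccccc1n2Cc1cn(CC(O)CO)nn1` gives 1070 nM. Compound 2 `CN1CCN(CCCCn2c3c(c4ccccc42)C(=O)c2c[n+]([O-])c4ccccc4c2C3=O)CC1` carries a different chain on the shared core; in this assay compound 2 gives 80 nM, and on the two numbers at hand compound 2 stands lowest, set apart from compound 1 by the step of a 13-fold lower number from compound 1 to compound 2 (1.13 log units; beyond the scatter). Compound 3 `CCCN1CCN(CCCCn2c3c(c4ccccc42)C(=O)c2c[n+]([O-])c4ccccc4c2C3=O)CC1` is the next entry and has not yet been measured in this assay. Its difference from compound 2 is ethyl in place of hydrogen on a saturated chain carbon bound to an amine nitrogen in a ring. Among the compounds with values here, the single measured step, a 13-fold lower number from compound 1 to compound 2 (1.13 log units; beyond the scatter), exchanges the whole side chain at the aromatic nitrogen and so says nothing about lengthening the group on the saturated chain carbon bound to the amine nitrogen in a ring; no measured pair changes only that position, and no direction is indicated. The expected outcome for compound 3 is a 1.3-fold higher number from compound 2 to compound 3 (0.10 log units; within the scatter), a change no larger than the usual scatter. Compound 3 is therefore estimated at about 100 nM in this assay, with a range from 40 nM to 250 nM.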

Compound 3, half-maximal inhibitory concentration: 6830 nM
Beside the measured number, compound 3's estimate is 68-fold (1.83 log units) below it; measured number above the stated range.
By their numbers in this assay, from the lowest: compound 2; then compound 1; then compound 3.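

In this assay, within the data shown here, the change from 4-methylpiperazin-1-yl to 4-propylpiperazin-1-yl is the first measured change at this position alone, and it gives an 85-fold higher number from compound 2 to compound 3 (1.93 log units; beyond the scatter): ethyl in place of hydrogen on a saturated chain carbon bound to an amine nitrogen in a ring is enough for a large step. The exchange of the whole side chain at the aromatic nitrogen also no longer has one direction: a 13-fold lower number from compound 1 to compound 2 (1.13 log units; beyond the scatter) stands against a 6.4-fold higher number from compound 1 to compound 3 (0.81 log units; beyond the scatter), so among these three compounds its outcome depends on the group carried at this position. No measurement at hand accounts for the size of the step at this position or for the reversal in direction.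

Only methyl and propyl stand at this position, which leaves open whether the number climbs gradually with chain length or jumps at one particular length. A 4-ethylpiperazin-1-yl or a 4-butylpiperazin-1-yl chain would help to settle this, and an unsubstituted piperazin-1-yl or a 4-(2-hydroxyethyl)piperazin-1-yl chain would show whether the step is specific to simple alkyl groups.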